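A few compounds are considered here, and "the series" means these few. Any claim that something is new, unique, unknown or untested is made for them only; others in the source may bear on it.

Three compounds share one core and differ only in the aryl group on a saturated chain carbon bound to an aromatic nitrogen. Compound 1 `O=c1ccoc2cc(OCc3cn(Cc4ccccc4)nn3)ccc12` carries a plain phenyl there; in a functional assay on HeLa cells (Homo sapiens) for cytotoxicity, read by MTT assay, with a stated time of 48 h (a lower number here means a stronger inhibitor, a higher number a weaker inhibitor), compound 1 reaches only a limit, > 100000 nM, as the limit of > 100000 nM in this assay, at which 1 of the 3 values shown sits, records. Compound 2 `O=c1ccoc2cc(OCc3cn(Cc4ccc(Cl)cc4Cl)nn3)ccc12` carries a 2,4-dichlorophenyl and gives 80600 nM in this assay, which is an at least 1.2-fold lower number from compound 1 to compound 2 (0.09 log units; that floor lies within the scatter). Compound 3 `O=c1ccoc2cc(OCc3cn(Cc4cccc([N+](=O)[O-])c4)nn3)ccc12` carries a 3-nitrophenyl and gives 17300 nM in this assay, the lowest of the two numbers, reached by an at least 5.7-fold lower number from compound 1 to compound 3 (0.76 log units; beyond the scatter) and by a 4.7-fold lower number from compound 2 to compound 3 (0.67 log units; beyond the scatter). Compound 4 `O=c1ccoc2cc(OCc3cn(Cc4ccc([N+](=O)[O-])cc4)nn3)ccc12` has not been measured; it differs from compound 3 by 4-nitrophenyl in place of 3-nitrophenyl on a saturated chain carbon bound to an aromatic nitrogen. Among the compounds with values here, no measured step moves a nitro group from one ring carbon to another; the two steps into compound 3 only show that a nitrophenyl gave a lower number than a phenyl or a dichlorophenyl. The step is therefore expected to be a 1.2-fold lower number from compound 3 to compound 4 (0.06 log units; within the scatter), within the scatter. Compound 4 is estimated at 15000 nM in this assay, with a range from 5000 nM to 50000 nM.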

Compound 4, half-maximal inhibitory concentration: 25700 nM
Estimate against measurement, compound 4: 1.7-fold (0.23 log units) below, and the stated range covers the measured number.
By their numbers in this assay, from the lowest: compounds 3 and 4 (each within the scatter of the next); then compound 2. At a limit, above all of these: compound 1.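

Placing 4-nitrophenyl where 3-nitrophenyl stood gives a 1.5-fold higher number from compound 3 to compound 4 (0.17 log units; within the scatter) in this assay, so the two nitrophenyl groups cannot be told apart on a saturated chain carbon bound to an aromatic nitrogen. A second nitrophenyl now also gives a lower number than the 2,4-dichlorophenyl, with a 3.1-fold lower number from compound 2 to compound 4 (0.50 log units; beyond the scatter), so the earlier gap is no longer seen for one nitrophenyl alone. Against the plain phenyl, the result is an at least 3.8-fold lower number from compound 1 to compound 4 (0.59 log units; beyond the scatter), which is a floor and not a full size: the limit of > 100000 nM in this assay, at which 1 of the 4 values shown sits.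

The compounds shown leave open whether an amine or a carboxylic acid on the phenyl ring, in place of the nitro group, would give numbers like these. They also leave open what a longer chain would do in place of the saturated chain carbon.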